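Sulfamoylaminoethoxy extension of the oxadiazole ether in a fluoro-bromoanilide

A few compounds are considered here, and "the series" means these few. Any claim that something is new, unique, unknown or untested is made for them only; others in the source may bear on it.

Compound 1 `COc1nonc1/C(=N/O)Nc1ccc(F)c(Br)c1` gives 230 nM in an assay for inhibition of Indoleamine 2,3-dioxygenase 1 (Homo sapiens), read by fluorescence, with a stated time of 1 h (a lower number here means a stronger inhibitor, a higher number a weaker inhibitor), the higher of the two numbers in hand, though within the scatter of compound 2 `N#CCC(=O)NCCSc1nonc1/C(=N/O)Nc1ccc(F)c(C(F)F)c1`, which in this assay gives 180 nM. Compound 3 `NS(=O)(=O)NCCOc1nonc1/C(=N/O)Nc1ccc(F)c(Br)c1` differs from compound 1 by (sulfamoylamino)methyl in place of hydrogen on a saturated chain carbon bound to an oxygen on an aromatic ring. Among the compounds with values here, no measured pair isolates this change; compound 2 only shows that a longer chain on the core is tolerated. The step of a 1.5-fold lower number from compound 1 to compound 3 (0.19 log units; within the scatter) is expected to be small, at most a modest lowering, and not clearly beyond the scatter. Compound 3 is estimated at 150 nM, within 50 nM to 500 nM.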

Compound 3, half-maximal inhibitory concentration: 150 nM
For compound 3 middle estimate and measured number coincide at the digits printed, within the range that was stated.
By their numbers in this assay, from the lowest: compounds 3, 2 and 1 (each within the scatter of the next).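

In this assay, methoxy to 2-(sulfamoylamino)ethoxy gives a 1.5-fold lower number from compound 1 to compound 3 (0.19 log units; within the scatter), so the saturated chain carbon bound to an oxygen on an aromatic ring accepts this group with no change beyond the scatter. Compound 2 differs from compound 1 in more than one place, so this pair is the only one here that isolates the change. No measurement at hand bears on the reason for this result.

The compounds shown leave open whether the sulfamoylamino end matters, or the chain alone. A simple amine or carboxylic acid at the end of the ethoxy chain, or a longer chain carrying the same sulfamoylamino end, would separate the two.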